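Cytotoxicity limits and the step to compound 3

The source may hold more compounds than are shown below. What is called first, only, known or untested is meant among the compounds shown, and "the series" means these compounds.

compound 1 - `COc1c(Br)cc(Br)cc1C(=O)Nc1ccc(Sc2nc3ccccc3s2)c(Cl)c1` - > 100000 nM
compound 2 - `COc1c(Br)cc(Br)cc1C(=O)Nc1cccc(Cl)c1` - > 100000 nM

In an ADME assay on HEK293 cells (Homo sapiens) for cytotoxicity, read by reporter gene assay and resazurin assay, with a stated time of 48 h (a lower number here means that less compound is tolerated, a higher number that more compound is tolerated), compound 1 stands only at a limit, > 100000 nM, and not at a number. Among the compounds with values here, compound 2 likewise gives a limit, > 100000 nM, so that the whole series so far rests on the limit of > 100000 nM in this assay, at which 2 of the 2 values shown sit, and no true value is known.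

Compound 3 `O=C(Nc1ccc(Sc2nc3ccccc3s2)c(Cl)c1)c1ccccc1O` differs from compound 1 on the carbonyl carbon, where 2-hydroxyphenyl enters: a group of 7 heavy atoms (6 carbon, 1 oxygen; one six-membered aromatic ring of carbon only) in place of a group of 10 heavy atoms (7 carbon, 1 oxygen, 2 bromine; one six-membered aromatic ring of carbon only), on a carbonyl carbon. Within the data shown here, the only measured step, a step that the two limits leave unreadable from compound 1 to compound 2, concerns a different place and offers no size to carry over. The expected step, an at least 1.4-fold lower number from compound 1 to compound 3 (0.15 log units; that floor lies within the scatter), is therefore only a loose estimate, with any movement taken toward less compound tolerated and a further limit quite possible. The estimate for compound 3 is 70000 nM, with an expected range from 15000 nM to 100000 nM as a working figure.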

Compound 3, half-maximal cytotoxic concentration: 64000 nM
Estimate against measurement, compound 3: 1.1-fold (0.04 log units) above; the measured number falls inside the stated range.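

Within the data shown here, with 2-hydroxyphenyl on the carbonyl carbon, compound 3 gives 64000 nM in this assay, the first true number. Going by these compounds, the step is an at least 1.5-fold lower number from compound 1 to compound 3 (0.19 log units; that floor lies within the scatter), so a change at this position can bring the reading inside the measurable range, although the full size of the step stays unknown. Compound 1 and compound 2 each remain a limit and not a number: the limit of > 100000 nM in this assay, at which 2 of the 3 values shown sit.

The exchange swaps a group of 10 heavy atoms for one of 7 and adds a hydrogen-bond donor, and the compounds shown do not separate the loss of the two bromines from the entry of the hydroxy group. Also open, on these data alone, is how a 2-aminophenyl or a 2-carboxyphenyl group on the same carbonyl carbon would read in this assay.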